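The compounds below may be only part of what the source reports. "The series", "measured", "known", "first", "only" and "open" are said of these compounds alone.

Measured in a functional assay on A2780 cells (Homo sapiens) for antiproliferative activity, read by MTT assay, with a stated time of 48 h; a higher number here means a weaker inhibitor, a lower number a stronger inhibitor:
- Compound 1 `COc1ccc2c(/C=C/C(=O)c3cc(OC)c(OC)c(SC)c3)c[nH]c2c1`: 139 nM
- Compound 2 `COc1ccc2c(/C=C(\C)C(=O)c3cc(OC)c(OC)c([Se]C)c3)cn(C)c2c1`: 26 nM
- Compound 3 `COc1ccc2c(/C=C/C(=O)c3cc(OC)c(OC)c(SC)c3)cn(C)c2c1`: 145 nM

Compound 2 gives 26 nM, the lowest number of the three and clearly beyond the scatter of the other two. It is therefore the strongest inhibitor so far.

Compound 4 `COc1cc(C(=O)/C(C)=C/c2cn(C)c3ccccc23)cc([Se]C)c1OC` differs from it by hydrogen in place of methoxy on an aromatic carbon. Among the measured compounds shown here, no measured step covers this change, as all three measured compounds carry that methoxy. For the measured compounds named here, the only measured step, a 1.0-fold higher number from compound 1 to compound 3 (0.02 log units; within the scatter), is methyl in place of hydrogen on an aromatic nitrogen. It lies at another place and stays within the scatter, so it says little here.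

The size of the step must therefore remain an open guess. With compound 2 at 26 nM, the best of the set, a weaker result seems more likely than a stronger one, so a higher number is expected in this assay. The expected change, which is uncertain, is a 4.6-fold higher number from compound 2 to compound 4 (0.66 log units; beyond the scatter). For compound 4 the estimate is 120 nM, with an expected range from 30 nM to 600 nM.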

Compound 4, half-maximal inhibitory concentration: 35 nM
For compound 4 the middle estimate is 3.4-fold (0.54 log units) above the measured one; measured number inside the range.
By their numbers in this assay, from the lowest: compounds 2 and 4 (each within the scatter of the next); then compounds 1 and 3 (each within the scatter of the next).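

In this assay, hydrogen in place of methoxy on this aromatic carbon gives a 1.3-fold higher number from compound 2 to compound 4 (0.13 log units; within the scatter), so the numbers of the two compounds cannot be told apart. Every earlier compound carried this methoxy, so they could not show whether it was needed; this pair shows that, with the rest of the structure the same, losing it costs nothing beyond the scatter in this assay. No available evidence bears on why this is so.

As far as these compounds go, whether a hydroxyl group, an amine or a fluorine atom at this place would keep the number in the same range stays open. Also open, from the compounds shown here alone, is whether hydrogen in place of methoxy would give a similarly small step in compound 1 or compound 3, which share the methoxy but differ elsewhere from compound 2.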